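Cytotoxicity notes: amine ring change in the ester series

A few compounds are considered here, and "the series" means these few. Any claim that something is new, unique, unknown or untested is made for them only; others in the source may bear on it.

Measured so far:
compound 1 `CC1CCN(CCCC(=O)O[C@@H]2C[C@@H]3CC[C@@]2(C)C3(C)C)CC1` gives 171000 nM in an ADME assay on HEK-293T cells (Homo sapiens) for cytotoxicity, read by MTT assay, with a stated time of 48 h; a higher number here means that more compound is tolerated, a lower number that less compound is tolerated
compound 2 `CN1CCN(CCC(=O)O[C@@H]2C[C@@H]3CC[C@@]2(C)C3(C)C)CC1` gives 282000 nM in this assay

Compound 1 and compound 2 lie within the scatter of each other, so neither stands apart on these two numbers. Compound 3 `CC1(C)[C@H]2CC[C@]1(C)[C@H](OC(=O)CCCN1CCCCCC1)C2` is not yet measured. It differs from compound 1 by azepan-1-yl in place of 4-methylpiperidin-1-yl on a saturated chain carbon, three bonds along the chain from a carbonyl carbon. Within the data shown here, no step between measured compounds exists for this kind of change, and the two values at hand are close, so a step no larger than the scatter is expected, with no clear direction. Compound 3 is estimated at 200000 nM, within 90000 nM to 420000 nM, which is expected to mean a 1.2-fold higher number from compound 1 to compound 3 (0.07 log units; within the scatter).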

Compound 3, half-maximal cytotoxic concentration: 62200 nM
The estimate for compound 3 lay 3.2-fold (0.51 log units) above the measured number, outside the stated range (below it).
By their numbers in this assay, from the lowest: compound 3; then compounds 1 and 2 (each within the scatter of the next).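

In this assay, the ring amine on a saturated chain carbon, three bonds along the chain from a carbonyl carbon, is not interchangeable: azepan-1-yl in place of 4-methylpiperidin-1-yl gives a 2.7-fold lower number from compound 1 to compound 3 (0.44 log units; beyond the scatter). The two groups have the same atoms, joined differently, as a seven-membered and a six-membered ring, so rearranging those atoms alone is enough to shift the number. No available data bear on the origin of this step. Still open, on these data alone, is where piperidin-1-yl or morpholin-4-yl at this place would fall relative to these two groups.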